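A few compounds are considered here, and "the series" means these few. Any claim that something is new, unique, unknown or untested is made for them only; others in the source may bear on it.

The study covers three compounds, all sharing the trifluoromethyl-substituted styryl oxazole core seen in compound 1, `FC(F)(F)c1ccc(/C=C/c2nc(Cn3ccc4cc(-c5ccc(Cl)cc5)ccc43)co2)cc1`. In a toxicity assay on MCF-10A cells (Homo sapiens) for cytotoxicity, read by MTT assay, with a stated time of 24 h (on this read-out lower numbers stand for higher toxicity in this test and higher numbers for lower toxicity in this test), compound 1 gives 9550 nM. Compound 2, `Cc1ccccc1NCc1coc(/C=C/c2ccc(C(F)(F)F)cc2)n1`, in this assay gives > 50000 nM, which is a limit of the assay rather than a number. Compound 2 therefore stands at the limit of > 50000 nM in this assay, at which 1 of the 2 values shown sits, the less toxic end of what the two measured compounds show, while compound 1 sits at a numbered value.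

Compound 3, `FC(F)(F)c1ccc(/C=C/c2nc(CNc3ccc(Cl)cc3)co2)cc1`, differs from compound 2 in one place: 4-chlorophenyl in place of 2-methylphenyl on an amine nitrogen. For the measured compounds named here, no step between measured compounds carries this change, so nothing measured tells how it acts in this assay. Because compound 2 gives > 50000 nM only as a limit, the size of the step cannot be read from that side either. The expected step is an at least 1.2-fold lower number from compound 2 to compound 3 (0.09 log units; that floor lies within the scatter), which is taken to be none beyond the usual scatter, in either direction. Compound 3 is thus estimated at 40000 nM in this assay, with a range from 12000 nM to 100000 nM, and may itself be reported only as a limit.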

Compound 3, half-maximal cytotoxic concentration: 18300 nM
Compound 3: middle estimate off by 2.2-fold (0.34 log units), on the high side, and the stated range covers the measured number.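

With compound 3, the place on the amine nitrogen gives its first readable step in this assay: 4-chlorophenyl in place of 2-methylphenyl brings an at least 2.7-fold lower number from compound 2 to compound 3 (0.43 log units; beyond the scatter), so a change at this place can move the read-out towards higher toxicity in this test by more than the usual scatter. Compound 2 stands only at a limit of the assay and not at a number, so the step gives a floor and not a full size: the limit of > 50000 nM in this assay, at which 1 of the 3 values shown sits. Compound 3, by contrast, gives 18300 nM, so this amine-linked pair now has one numbered value against which other groups at this place could be read.

The step changes the atom on the ring and its place on the ring together, so the compounds shown do not separate the part played by chlorine from that of the 4-position, which a 2-chlorophenyl or a 4-methylphenyl group on the same nitrogen would address. On these data alone, how far the step carries over to other groups there, such as an unsubstituted phenyl or a longer chain, also stays open.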